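The source may report more compounds than this note shows. Statements on the series, on what has been measured and on what is new or still open speak of the compounds shown alone.

Measured compounds:
compound 1 `O=S(=O)(c1ccccc1)n1cc(-c2ccccc2)c2ccccc21`, 146 nM
compound 2 `CS(=O)(=O)n1ccc2ccc(-c3ccncc3)cc21`, 4050 nM

In an assay on isolated protein for displacement of a labelled ligand from 5-hydroxytryptamine receptor 6 (Homo sapiens), read by scintillation counting, with a stated time of 1 h (on this read-out lower numbers stand for stronger inhibition and higher numbers for weaker inhibition), compound 2 gives 4050 nM, the highest of the two numbers. Within the data shown here, its nearest neighbour is compound 1, which gives 146 nM; the gap between them lies beyond the scatter, but the two structures differ in more than one place, so the two values show only that compound 1 sits far below compound 2.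

Compound 3 `O=S(=O)(N1CCCCC1)n1ccc2ccc(-c3ccncc3)cc21` is not yet measured. It differs from compound 2 in one place: piperidin-1-yl in place of methyl on a sulfonyl sulfur. Among the measured compounds shown here, no step between measured compounds matches this change, so the expectation rests on the position of compound 2 alone. The step from compound 2 to compound 3 is expected to be a 2.7-fold lower number from compound 2 to compound 3 (0.43 log units; beyond the scatter), toward a lower number, though a result within the scatter would not surprise. Compound 3 is estimated at 1500 nM in this assay, within a range from 300 nM to 6000 nM.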

Compound 3, inhibition constant: 1660 nM
Compound 3: the middle estimate sits 1.1-fold (0.04 log units) below what was measured; measured number inside the range.
By their numbers in this assay, from the lowest: compound 1; then compound 3; then compound 2.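

In this assay, putting piperidin-1-yl in place of methyl on a sulfonyl sulfur gives a 2.4-fold lower number from compound 2 to compound 3 (0.39 log units; beyond the scatter). Among these compounds, this is the first change read at this position, and it shows that a group of six heavy atoms with a six-membered non-aromatic ring can stand there without raising the number; the number instead falls modestly, beyond the scatter. Nothing available bears on why the number falls with this change.

As far as these compounds go, it remains open whether a morpholin-4-yl group, an open-chain diethylamino group or a simple ethyl group on the same sulfonyl sulfur would give a number nearer that of compound 2 or that of compound 3. From the compounds shown here alone, it is also open whether the same change would give a similar step on the core of compound 1.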